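The compounds below may be only part of what the source reports. "The series", "measured", "known", "first", "only" and "open" are said of these compounds alone.

Measured compounds:

Compound 1 `O=C(Nc1ccccc1OC(F)(F)F)Nc1n[nH]c2ccccc12`, in a functional assay on COLO 205 cells (Homo sapiens) for inhibition, read by sulforhodamine B assay, with a stated time of 48 h (on this read-out higher numbers stand for weaker inhibition of growth and lower numbers for stronger inhibition of growth), compound 1 gives 71800 nM.
Compound 2 `Nc1nn(C(=O)Nc2ccc(Cc3ccccc3)cc2)c2ccccc12`, in this assay compound 2 gives 13400 nM.
Compound 3 `COc1ccccc1NC(=O)n1nc(N)c2ccccc21`, in this assay compound 3 gives > 100000 nM, a limit of the assay and not a number (the limit of > 100000 nM in this assay, at which 1 of the 3 values shown sits).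

Of the two numbers in hand, compound 2 stands lowest; the nearest is compound 1, whose number is higher by a margin beyond the usual scatter. Compound 3 shares the core of compound 2 and reaches only a limit.

Compound 4 `CCCCOc1ccc(NC(=O)n2nc(N)c3ccccc32)cc1` is not yet measured. It differs from compound 2 in one place: butoxy in place of benzyl on an aromatic carbon. For the measured compounds named here, no measured pair shows this exact change, so the size of the step can only be judged from the two compounds that share the core. Compound 3, carrying an alkoxy group on the same ring, gives only a limit, while compound 2 with benzyl gives a number; on that basis the expectation is a step toward weaker inhibition from compound 2 to compound 4, of about a 2.6-fold higher number from compound 2 to compound 4 (0.42 log units; beyond the scatter). Compound 4 is therefore estimated at 35000 nM, in a range from 10000 nM to 100000 nM.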

Compound 4, concentration for 50% growth inhibition: 13900 nM
Estimate against measurement, compound 4: 2.5-fold (0.40 log units) above; the range from low to high includes it.
By their numbers in this assay, from the lowest: compounds 2 and 4 (each within the scatter of the next); then compound 1. At a limit, above all of these: compound 3.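

In this assay, putting butoxy in place of benzyl on an aromatic carbon, para to a large group, gives a 1.0-fold higher number from compound 2 to compound 4 (0.02 log units; within the scatter). The earlier compounds shown here held no pair that differed at this place, and this pair shows that the six-membered aromatic ring of benzyl is not needed here to stay within the scatter: butoxy has no ring, fewer heavy atoms and one hydrogen-bond acceptor. Nothing measured here accounts for this result.

As far as these compounds go, it remains open whether an amine, a carboxylic acid or a longer chain at this place would also stay within the scatter of compound 2. Compound 3 gives > 100000 nM, a limit of the assay and not a number, and steps to it cannot be read.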